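The compounds below may be only part of what the source reports. "The series", "measured", "known", "first", "only" and "open" are said of these compounds alone.

Compound 1 `CCCCCNC(=O)[C@H]1O[C@@H](n2cnc3c(N)ncnc32)[C@H](O)[C@@H]1O`: 12 nM in an assay on cell membranes for binding affinity to 2-oxoglutarate receptor 1 (Rattus norvegicus), read by radioligand binding; on this read-out higher numbers stand for weaker inhibition and lower numbers for stronger inhibition
Compound 2 `NCCCCCCCCNC(=O)[C@H]1OC(n2cnc3c(N)ncnc32)[C@H](O)[C@@H]1O`: 29 nM
Compound 3 `Nc1ncnc2c1ncn2[C@@H]1O[C@H](C(=O)NC2CCCC2)[C@@H](O)[C@H]1O`: 49 nM

Compound 3 gives the highest number of the three in this assay. Its nearest neighbour is compound 2, whose value is within the scatter of that of compound 3, so no order between the two can be claimed. Among the measured compounds shown here, the only step beyond the scatter is a 4.1-fold higher number from compound 1 to compound 3 (0.61 log units; beyond the scatter), a modest weakening.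

Compound 4 `C[C@H]1CC[C@H](NC(=O)[C@H]2O[C@@H](n3cnc4c(N)ncnc43)[C@H](O)[C@@H]2O)CC1` differs from compound 3 in one place: 4-methylcyclohexyl in place of cyclopentyl on an amide-type nitrogen. For the measured compounds named here, no measured pair shows a ring enlarged or a methyl added to a ring on this nitrogen, so the step from compound 1 to compound 3 is the only one that bears on it, and only loosely, since it compares an open chain with a ring rather than two rings. On that basis compound 4 is expected to land near compound 3, with the step of a 1.6-fold lower number from compound 3 to compound 4 (0.21 log units; within the scatter) likely to stay within or just beyond the scatter. The estimate for compound 4 is 30 nM, with a range from 8 nM to 120 nM.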

Compound 4, inhibition constant: 12.9 nM
Beside the measured number, compound 4's estimate is 2.3-fold (0.37 log units) above it, within the range that was stated.
By their numbers in this assay, from the lowest: compounds 1 and 4 (each within the scatter of the next); then compounds 2 and 3 (each within the scatter of the next).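

On the amide-type nitrogen, the identity of the ring matters in this assay: 4-methylcyclohexyl in place of cyclopentyl gives a step beyond the scatter (a 3.8-fold lower number from compound 3 to compound 4 (0.58 log units; beyond the scatter)). The weakening seen with cyclopentyl in place of pentyl (a 4.1-fold higher number from compound 1 to compound 3 (0.61 log units; beyond the scatter)) therefore does not extend to every ring at this position, and 4-methylcyclohexyl in place of pentyl stays within the scatter (a 1.1-fold higher number from compound 1 to compound 4 (0.03 log units; within the scatter)), so no order can be claimed between that pair. Nothing available here offers an explanation for the difference between the two rings.

The change alters both the ring and the methyl at once, and an unsubstituted cyclohexyl on this nitrogen would be needed to separate the two. As far as these compounds go, how a cycloheptyl or a 4-hydroxycyclohexyl would read in this assay also remains open.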